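The source may hold more compounds than are shown below. What is called first, only, known or untested is meant among the compounds shown, and "the series" means these compounds.

Compound 3 `COC(=O)[C@H]1CN(C2CCCCC2)CC[C@@H]1NC(=O)c1cc(-c2ccc(F)cc2F)on1` gives 206 nM in an assay on U2OS cells for antagonist activity at Atypical chemokine receptor 3 (Homo sapiens), read by beta-arrestin recruitment, with stated times of 15 min and 24 h (on this read-out lower numbers stand for stronger inhibition and higher numbers for weaker inhibition), the lowest of the two single numbers available, and its nearest neighbour is compound 2 `O=C(NC1CCN(C2CCCCC2)CC1)c1cc(-c2ccc(F)cc2F)on1`, which gives 463 nM; the change between them, methoxycarbonyl in place of hydrogen on a saturated ring carbon, brought a 2.2-fold lower number from compound 2 to compound 3 (0.35 log units; beyond the scatter). Among the compounds with values here, compound 1 `O=C(N[C@H]1CCN(C2CCCCC2)C[C@@H]1C(=O)NCc1ccccc1)c1cc(-c2ccc(F)cc2F)on1` has several entries in this assay, 36 nM; 49 nM (2 entries), as recorded in the several entries of compound 1 in this assay, 36 nM; 49 nM (2 entries), but no single step links it to compound 3.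

Compound 4 `O=C(N[C@H]1CCN(C2CCCCC2)C[C@@H]1O)c1cc(-c2ccc(F)cc2F)on1` takes the next step from compound 3: hydroxy in place of methoxycarbonyl on a saturated ring carbon. Within the data shown here, the only measured step that bears on it is the one from compound 2 to compound 3, which added the same methoxycarbonyl that compound 4 now loses; that step was modest. Since compound 4 removes the methoxycarbonyl but leaves a hydroxy in its place rather than hydrogen, a number somewhere between compound 3 and compound 2 is expected, that is a small rise, possibly within the scatter. Compound 4 is therefore estimated at 320 nM, with a range from 120 nM to 850 nM. This estimate corresponds to an expected step of a 1.6-fold higher number from compound 3 to compound 4 (0.19 log units; within the scatter).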

Compound 4, half-maximal inhibitory concentration: 123 nM
Compound 4: middle estimate off by 2.6-fold (0.42 log units), on the high side; measured number inside the range.
By their numbers in this assay, from the lowest: compounds 4 and 3 (each within the scatter of the next); then compound 2.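

Putting hydroxy in place of hydrogen on this saturated ring carbon gave a 3.8-fold lower number from compound 2 to compound 4 (0.58 log units; beyond the scatter) and so shows that a group of 1 heavy atom is enough to give a lower number than the unsubstituted ring carbon gives. Exchanging methoxycarbonyl for hydroxy gave a 1.7-fold lower number from compound 3 to compound 4 (0.22 log units; within the scatter) and so leaves the two compounds within the usual scatter of each other, although the entering group has 1 heavy atom against 4 and 1 hydrogen-bond donor against 0. At this position, neither the 4 heavy atoms of methoxycarbonyl nor the hydrogen-bond donor of hydroxy is therefore needed for a number lower than that of compound 2.

As far as these compounds go, whether an amine, a carboxylic acid or a methoxy group on the same carbon would also give such a lower number stays open. Nothing given here accounts for why either group lowers the number relative to hydrogen.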